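Thioether acids: aryl swap at the distal ether

This account rests on a few compounds, and the source may have more. Where it says the series, first, only, none or still open, it means among the compounds named here.

Compound 1 `CCCCC(Sc1ccc(OCCCOc2ccccc2OC)cc1)C(=O)O` is measured in an assay on isolated protein for inhibition of Polyunsaturated fatty acid 5-lipoxygenase (Homo sapiens), read by HPLC, with a stated time of 15 min, in the presence of a further agent that is not named here (a higher number here means a weaker inhibitor, a lower number a stronger inhibitor), only as a limit: compound 1 gives > 10000 nM. Compound 3 `Cc1cccc(OCCCOc2ccc(SCC(=O)O)cc2)c1C` likewise reaches only a limit, giving > 10000 nM. Compound 2 `CCCCC(Sc1ccc(OCCCOc2ccc3ncccc3c2)cc1)C(=O)OCC` gives 800 nM in this assay. Compound 1 stands at the limit of > 10000 nM in this assay, at which 2 of the 3 values shown sit, so no number for it is known, only that it is weak. Compound 4 `CCCCC(Sc1ccc(OCCCOc2ccc(C)cc2)cc1)C(=O)O` differs from compound 1 by 4-methylphenyl in place of 2-methoxyphenyl on an oxygen on a saturated carbon. Going by the values given here, no measured pair isolates this change. Expected is a number no higher from compound 1 to compound 4 (the limit leaves the size open), no more than the scatter, in no firm direction. Compound 4 is therefore estimated at 10000 nM, within 2500 nM to 40000 nM, with a fair chance that only a limit is again reported.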

Compound 4, half-maximal inhibitory concentration: 5200 nM
Compound 4: middle estimate off by 1.9-fold (0.28 log units), on the high side; the measured number falls inside the stated range.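

In this assay, 4-methylphenyl in place of 2-methoxyphenyl on an oxygen on a saturated carbon gives an at least 1.9-fold lower number from compound 1 to compound 4 (0.28 log units; that floor lies within the scatter). Compound 4 reads as a real number, 5200 nM, so this position can move the carboxylic acid on the core of compound 1 into the measurable range. The size of the step stays open because the value of compound 1 is a limit: the limit of > 10000 nM in this assay, at which 2 of the 4 values shown sit.

A plain phenyl or a 4-methoxyphenyl at this place would separate removing the 2-methoxy group from adding the 4-methyl group. Neither is among the compounds shown, so the two parts of this change cannot yet be told apart.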